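Swapping the amide ring on a dimethoxyphenyl isoxazole

The source may hold more compounds than are shown below. What is called first, only, known or untested is meant among the compounds shown, and "the series" means these compounds.

Compound 1 `COc1ccc(OC)c(-c2cc(-c3ccc(C(=O)N(C)C)s3)on2)c1` carries a dimethylamino group on its amide carbonyl. In a functional assay on PC-3 cells (Homo sapiens) for cytotoxicity, read by XTT assay, with a stated time of 72 h (a lower number here means a stronger inhibitor, a higher number a weaker inhibitor), compound 1 gives only a limit, > 30000 nM, so its true value is not known beyond that edge. Two related compounds in which the dimethoxyphenyl ring is replaced by a quinone ring give a point of comparison. Compound 2 `O=C1C=CC(=O)C(c2cc(-c3ccc(C(=O)N4CCCC4)s3)on2)=C1` also returns only a limit in this assay, < 30000 nM. Compound 3 `CN(C)C(=O)c1ccc(-c2cc(C3=CC(=O)C=CC3=O)no2)s1` gives a readable value of 7200 nM in this assay. The pair of compound 2 and compound 3 differs exactly in the amide group, yet the step that the limit leaves unreadable from compound 2 to compound 3 cannot be sized, as one end of it rests on a limit.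

Compound 4 `COc1ccc(OC)c(-c2cc(-c3ccc(C(=O)N4CCCC4)s3)on2)c1` is the untested partner of compound 1, differing by pyrrolidin-1-yl in place of dimethylamino on a carbonyl carbon. Going by the values given here, the only step of the same kind among the measured compounds is unreadable, so it offers no direction. Compound 1 rests at a limit, and nothing shown suggests the pyrrolidin-1-yl ring pulls a dimethoxyphenyl compound into the measurable range. The expected step that the limit leaves unreadable from compound 1 to compound 4 is therefore essentially none beyond the scatter. Compound 4 is expected to give about 40000 nM, with a plausible range from 12000 nM to 150000 nM.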

Compound 4, half-maximal inhibitory concentration: > 30000 nM
Compound 4: no number, only a limit; the forecaster's own chance of this, stated with the estimate: 75%; the middle value does not contradict the limit.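

Going by these compounds alone, compound 4 gives only a limit in this assay, and compound 1 does too, so no step between compound 1 and compound 4 can be read. The compounds shown leave open how far each lies past that limit, and whether pyrrolidin-1-yl in place of dimethylamino on a carbonyl carbon changes anything on the core of compound 1.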